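A few compounds are considered here, and "the series" means these few. Any claim that something is new, unique, unknown or untested is made for them only; others in the source may bear on it.

Measured so far:
compound 1, `CC(C)CSc1nc(N)nc2c1ncn2/C=C1/CC1(CO)CO`, 60000 nM
compound 2, `CC(C)Nc1nc(N)nc2c1ncn2/C=C1/CC1(CO)CO`, > 20000 nM

In an ADME assay on CCRF-HSB-2 cells (Homo sapiens) for cytotoxicity, with a stated time of 7 days (a higher number here means that more compound is tolerated, a lower number that less compound is tolerated), compound 1 gives 60000 nM. For compound 2 the reading in this assay is > 20000 nM, which is a limit of the assay rather than a number. Compound 2 thus sits at the limit of > 20000 nM in this assay, at which 1 of the 2 values shown sits. Going by the values given here, the only measured step, a step that the limit leaves unreadable from compound 1 to compound 2, cannot be given a size for that reason.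

The next compound is compound 3, `Nc1nc(SCc2ccccc2)c2ncn(/C=C3/CC3(CO)CO)c2n1`. Against compound 2 the change is benzylsulfanyl in place of isopropylamino on an aromatic carbon. Compound 3 therefore carries, like compound 1, a sulfanyl group in place of an amino group at that position, so its closest measured relative by make-up is compound 1 rather than compound 2. Among the compounds with values here, only the one step bears on the change, and its size is not readable, so it gives no direction. Within the data shown here, the single numerical anchor is compound 1 at 60000 nM.

Compound 3 is estimated to lie near 50000 nM, within 15000 nM to 150000 nM. The step this estimate means, a step that the limit leaves unreadable from compound 2 to compound 3, is expected to remain unreadable because compound 2 sits at the limit of > 20000 nM in this assay, at which 1 of the 2 values shown sits.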

Compound 3, half-maximal cytotoxic concentration: > 100000 nM
Compound 3: a limit, no number (the forecaster's own chance of this, stated with the estimate: 40%); middle value at least 2.0-fold (0.30 log units) away from the limit.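

Compound 1 and compound 3 both carry a sulfanyl group at this position and differ only in phenyl in place of isopropyl on a saturated chain carbon bound to a sulfur, and in this assay this change gives an at least 1.6-fold higher number from compound 1 to compound 3 (0.22 log units; that floor lies within the scatter). Going by these compounds alone, compound 3 has a limit of the assay, not a number: the limit of > 100000 nM in this assay, at which 1 of the 3 values shown sits. The floor of this step lies within the usual scatter, so it shows no firm rise, but it does show that putting an aromatic ring on the sulfanyl chain gives no sign of less compound being tolerated than with the isopropyl end of compound 1.

The step from compound 2 to compound 3 has a limit at both ends and cannot be read, so the compounds shown do not settle how a sulfanyl group compares with an amino group at this position. Also open, on these data alone, are the real size of the step from the isopropyl end to the phenyl end, and what a longer chain on the sulfur or a carboxylic acid on the phenyl ring would do.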